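Replacing the (cyclopropylmethyl)sulfamoyl group of compound 3

The source may report more compounds than this note shows. Statements on the series, on what has been measured and on what is new or still open speak of the compounds shown alone.

Of the compounds shown here, three with a shared core have been tested in an ADME assay (liver) for metabolic stability, with Liver microsome (Rattus norvegicus) as the target, using microsomes and NADPH, with a stated time of 30 min; on this read-out higher numbers stand for fast clearance and lower numbers for slow clearance. Compound 1 `CC#C[C@H]1CN(S(=O)(=O)c2ccc(N)nc2)CCN1c1ccccc1` gives > 399 mL.min-1.g-1, which is a limit of the assay and not a number. Compound 2 `CC#C[C@H]1CN(S(=O)(=O)c2ccc(N)nc2)CCN1c1ccc(S(N)(=O)=O)cc1` gives 30 mL.min-1.g-1, and compound 3 `CC#C[C@H]1CN(S(=O)(=O)c2ccc(N)nc2)CCN1c1ccc(S(=O)(=O)NCC2CC2)cc1` gives 213 mL.min-1.g-1, the higher of the two true numbers.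

Putting sulfamoyl in place of hydrogen on an aromatic carbon gave an at least 13-fold lower number from compound 1 to compound 2 (1.12 log units; beyond the scatter). Putting (cyclopropylmethyl)sulfamoyl there instead gave an at least 1.8-fold lower number from compound 1 to compound 3 (0.27 log units; that floor lies within the scatter). Adding cyclopropylmethyl to the sulfonamide nitrogen gave a 7.1-fold higher number from compound 2 to compound 3 (0.85 log units; beyond the scatter).

Compound 4 `CC#CCC(O)(c1ccc(N2CCN(S(=O)(=O)c3ccc(N)nc3)C[C@@H]2C#CC)cc1)C(F)(F)F` changes that same aromatic carbon of compound 3: a group of 10 heavy atoms (6 carbon, 1 oxygen, 3 fluorine; no ring) in place of a group of 8 heavy atoms (4 carbon, 1 nitrogen, 2 oxygen, 1 sulfur; one three-membered non-aromatic ring of carbon only), on an aromatic carbon. Within the data shown here, no measured step brings in a group like the new one, so the evidence is only indirect. The steps do show that changes at this carbon can push the number either way, down in an at least 13-fold lower number from compound 1 to compound 2 (1.12 log units; beyond the scatter) and up in a 7.1-fold higher number from compound 2 to compound 3 (0.85 log units; beyond the scatter), so no firm direction follows for the new group. A small fall is expected, and no step beyond the scatter is expected, as in the estimated 1.4-fold lower number from compound 3 to compound 4 (0.15 log units; within the scatter). The estimated value for compound 4 is 150 mL.min-1.g-1, with an expected range from 45 mL.min-1.g-1 to 380 mL.min-1.g-1.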

Compound 4, intrinsic clearance in microsomes: 115 mL.min-1.g-1
Compound 4: middle estimate off by 1.3-fold (0.12 log units), on the high side; low and high end bracket the measured number.
By their numbers in this assay, from the lowest: compound 2; then compounds 4 and 3 (each within the scatter of the next). At a limit, above all of these: compound 1.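

In this assay, putting the new group in place of hydrogen on this aromatic carbon, para to a large group, gave an at least 3.4-fold lower number from compound 1 to compound 4 (0.54 log units; beyond the scatter), so a clear fall from the hydrogen compound does not depend on a sulfonamide, since the new group holds neither sulfur nor nitrogen. Going by these compounds, the true size of that fall stays unknown, because compound 1 stands at a limit of the assay and not at a number: the limit of > 399 mL.min-1.g-1 in this assay, at which 1 of the 4 values shown sits. Against the plain sulfamoyl group the new group gave a 3.8-fold higher number from compound 2 to compound 4 (0.58 log units; beyond the scatter), while against the (cyclopropylmethyl)sulfamoyl group it gave a 1.9-fold lower number from compound 3 to compound 4 (0.27 log units; within the scatter), so the two cannot be told apart here and compound 2 keeps the lowest number of the series.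

On these data alone, it remains open which part of the new group matters, for instance whether the same group without its three fluorine atoms, or with a shorter chain in place of its triple-bonded one, would behave alike. As far as these compounds go, it is equally open whether a small group such as an amine or a carboxylic acid on this carbon would reach a number as low as that of compound 2.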